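The source may report more compounds than this note shows. Statements on the series, on what has been measured and on what is new or still open speak of the compounds shown alone.

Compound 1 `CCOC(=O)c1ccc(-c2nn(CC)c3ccccc23)cc1`: > 10000 nM
Compound 2 `CC(C)OC(=O)c1ccc(-c2nn(Cc3ccccc3)c3ccccc23)cc1`: > 10000 nM

Both compounds were tested in a functional assay on cells (Platelet, Homo sapiens) for inhibition; a lower number here means a stronger inhibitor, a higher number a weaker inhibitor. For compound 1, > 10000 nM is a limit of the assay and not a number. For compound 2, > 10000 nM is also a limit and not a number. Compound 2 therefore has no exact position on the scale, and it shares its mark with compound 1: the limit of > 10000 nM in this assay, at which 2 of the 2 values shown sit.

Compound 3 `CO/N=C\c1ccc(-c2nn(Cc3ccccc3)c3ccccc23)cc1` keeps the core of compound 2 and changes one group, on an aromatic carbon of a six-membered aromatic ring of carbon only, para to a large group: a group of 4 heavy atoms (2 carbon, 1 nitrogen, 1 oxygen; no ring) in place of a group of 6 heavy atoms (4 carbon, 2 oxygen; no ring), on an aromatic carbon. The isopropoxycarbonyl leaves, and a smaller group with no common name enters.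

Among the measured compounds shown here, no measured step shows how far this assay responds to any change. Resting on (the limit of > 10000 nM in this assay, at which 2 of the 2 values shown sit), the expectation for compound 3 is no step beyond the scatter, although a move towards stronger inhibition remains possible. The estimated change is a step that the limit leaves unreadable from compound 2 to compound 3. For compound 3 the expected value is 12000 nM. The estimated range for compound 3 runs from 3000 nM to 40000 nM.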

Compound 3, half-maximal inhibitory concentration: > 10000 nM
Compound 3 was reported as a limit; the forecaster's own chance of this, stated with the estimate: 65%; the middle value is on the limit's open side.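

In this assay compound 3 gives > 10000 nM, which is a limit of the assay and not a number. Among the compounds shown here, compound 2 also stands at a limit, so no step between compound 2 and compound 3 can be read. The compounds shown leave open whether any change in this series can bring a measurable inhibition at all.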